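Adding a second chloro to the core of compound 2

A few compounds are considered here, and "the series" means these few. Any claim that something is new, unique, unknown or untested is made for them only; others in the source may bear on it.

Of the compounds shown here, three have been measured in a functional assay on SF-295 cells (Homo sapiens) for cytotoxicity, read by sulforhodamine B assay, with a stated time of 48 h; a higher number here means a weaker inhibitor of growth, a lower number a stronger inhibitor of growth. Compound 1 `ClCc1cccc(Cn2cnc3c(Cl)ncnc32)c1` gives 3230 nM, compound 2 `ClCc1ccccc1Cn1cnc2ncnc(Cl)c21` gives 7940 nM, and compound 3 `ClCc1cccc(Cn2cnc3nc(Cl)nc(Cl)c32)c1` gives 1860 nM. Compound 2 stands at the highest number of the three: the nearest, compound 1, sits lower by a margin beyond the scatter, and the furthest, compound 3, sits lower still, also beyond the scatter. Compounds 1 and 3 share the same arrangement of the chloromethyl benzyl group and differ from each other only in a second chloro on the core; their two values sit close together.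

Compound 4 `ClCc1ccccc1Cn1cnc2nc(Cl)nc(Cl)c21` carries that same second chloro onto the core of compound 2. The difference between them is chloro in place of hydrogen on an aromatic carbon. Going by the values given here, no measured pair with the same change has been given, so the size of the step is open. Compound 4 is therefore expected to give a somewhat lower number than compound 2, a modest step of about a 1.6-fold lower number from compound 2 to compound 4 (0.20 log units; within the scatter) in this assay, not certainly beyond the scatter. Compound 4 is estimated at 5000 nM, with a likely range from 2000 nM to 12500 nM.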

Compound 4, concentration for 50% growth inhibition: 20000 nM
Beside the measured number, compound 4's estimate is 4.0-fold (0.60 log units) below it; measured number outside the range, above it.
By their numbers in this assay, from the lowest: compounds 3 and 1 (each within the scatter of the next); then compound 2; then compound 4.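

In this assay, chloro in place of hydrogen on the aromatic carbon between two ring nitrogen atoms gives a 2.5-fold higher number from compound 2 to compound 4 (0.40 log units; beyond the scatter) on this core, a change modest in size but beyond the scatter, so this position does not accept the added chloro without a loss of growth inhibition here. The earlier compounds shown here did not show this: compound 1 at 3230 nM and compound 3 at 1860 nM also differ by a second chloro on the core, yet their values lie within the scatter of each other. The same change on the aromatic carbon therefore does not read the same in the two pairs, though those pairs differ from each other in more than one place, and the two cases alone set no general rule for this chloro.

As far as these compounds go, whether an amine, a methoxy group or a methyl group on this carbon would shift the number as chloro does on the core of compound 2, or leave it in place as on the core of compound 1, remains open. Nothing shown here offers an account of why the step from hydrogen to chloro differs between the two pairs.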